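The compounds below may be only part of what the source reports. "The series", "measured", "known", "first", "only" and "open" are said of these compounds alone.

Compound 1 `O=C(N/N=C/c1c(-c2cc3ccc(Br)cc3oc2=O)[nH]c2ccccc12)c1ccc(Cl)cc1` and compound 2 `O=C(N/N=C/c1c(-c2cc3ccc(Br)cc3oc2=O)[nH]c2ccccc12)c1ccccc1F` share one core and differ only in the ring attached to the carbonyl carbon. In a functional assay on MCF7 cells (Homo sapiens) for inhibition, read by MTT assay, with a stated time of 48 h (a lower number here means a stronger inhibitor, a higher number a weaker inhibitor), compound 1 gives 13800 nM. For compound 2 this assay reports only a limit, > 200000 nM, so its true number is not known. Among the measured compounds shown here, the one measured step, an at least 14-fold higher number from compound 1 to compound 2 (1.16 log units; beyond the scatter), is therefore read against that limit (the limit of > 200000 nM in this assay, at which 1 of the 2 values shown sits). Compound 3 `O=C(N/N=C/c1c(-c2cc3ccc(Br)cc3oc2=O)[nH]c2ccccc12)c1cccc(Br)c1` brings the next change: 3-bromophenyl in place of 2-fluorophenyl on a carbonyl carbon. Its ring carries a halogen, as the rings of compound 1 and compound 2 do, but a different one at a different place, so neither measured compound is a direct guide. For the measured compounds named here, the single measured step shows that changing the halogen and its place on this ring can shift this assay strongly. Compound 3 is expected to fall between the two known cases and somewhat nearer to compound 1. The expected step is an at least 6.6-fold lower number from compound 2 to compound 3 (0.82 log units; beyond the scatter). Compound 3 is therefore estimated at 30000 nM, within a range from 8000 nM to 200000 nM.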

Compound 3, half-maximal inhibitory concentration: > 200000 nM
Compound 3: no number, only a limit; the forecaster's own chance of this, stated with the estimate: 30%; at least 6.6-fold (0.82 log units) between middle value and limit.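

On this carbonyl carbon, 3-bromophenyl in place of 4-chlorophenyl gives an at least 14-fold higher number from compound 1 to compound 3 (1.16 log units; beyond the scatter) in this assay. A second ring with a different halogen at a different place has now also failed to give a measured number, and among the compounds shown only the 4-chlorophenyl ring of compound 1 does: the limit of > 200000 nM in this assay, at which 2 of the 3 values shown sit. Compound 2 and compound 3 both stand at that limit, and the step between them cannot be read, which leaves the 2-fluorophenyl and 3-bromophenyl rings unranked against each other.

The 4-chlorophenyl ring differs from the other two rings both in its halogen and in that halogen's place, and the compounds shown do not separate these two changes, a question that 3-chlorophenyl or 4-bromophenyl would address. Also open, on these data alone, is how this position responds to a plain phenyl ring without a halogen, or to a ring carrying an amine or a carboxylic acid.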